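A few compounds are considered here, and "the series" means these few. Any claim that something is new, unique, unknown or untested is made for them only; others in the source may bear on it.

Measured compounds:
- Compound 1, `CNC(=O)c1cc(C(=O)NC2CC2)cn(Cc2ccc3nc[nH]c3c2)c1=O`: in a physicochemical assay for solubility, read by HPLC, in simulated intestinal fluid, with a stated time of 16 h, tested at 125 ug/mL (on this read-out higher numbers stand for higher solubility and lower numbers for lower solubility), compound 1 gives 225 ug/mL.
- Compound 2, `CNC(=O)c1cc(C(=O)NC2CC2)cn(Cc2cccc3cc[nH]c23)c1=O`: in this assay compound 2 gives 11 ug/mL.
- Compound 3, `CNC(=O)c1cc(C(=O)NC2CC2)cn(Cc2ccc(OC)cc2)c1=O`: in this assay compound 3 gives 263 ug/mL.

Compound 3 carries the largest number of the three shown, but its separation from compound 1 is small, a 1.2-fold higher number from compound 1 to compound 3 (0.07 log units; within the scatter), so the two are not distinguished here. Compound 2 sits far below both: a 24-fold higher number from compound 2 to compound 3 (1.38 log units; beyond the scatter), and likewise a 20-fold lower number from compound 1 to compound 2 (1.31 log units; beyond the scatter).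

Compound 4, `CNC(=O)c1cc(C(=O)NC2CC2)cn(Cc2cccc([C@@H](C)O)c2)c1=O`, is the next compound, not yet measured. It differs from compound 3 in one place:

3-(1-hydroxyethyl)phenyl in place of 4-methoxyphenyl on a saturated chain carbon bound to an aromatic nitrogen

The measured steps that bear on this change are the two that swap the group on the saturated chain carbon bound to the aromatic nitrogen. Moving between two fused bicyclic groups and the 4-methoxyphenyl gave one small step, a 1.2-fold higher number from compound 1 to compound 3 (0.07 log units; within the scatter), and one large step, a 24-fold higher number from compound 2 to compound 3 (1.38 log units; beyond the scatter). Within the data shown here, neither involves a 3-(1-hydroxyethyl)phenyl, so the data give no direct precedent for the step from compound 3 to compound 4. Since compound 3 and compound 1 both sit high and only compound 2 falls away, a step that stays within the scatter is expected, a 1.1-fold lower number from compound 3 to compound 4 (0.04 log units; within the scatter). Compound 4 is therefore estimated at 240 ug/mL, with a range from 110 ug/mL to 500 ug/mL.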

Compound 4, solubility: 495 ug/mL
Estimate against measurement, compound 4: 2.1-fold (0.31 log units) below; the measured number falls inside the stated range.
By their numbers in this assay, from the lowest: compound 2; then compounds 1, 3 and 4 (each within the scatter of the next, the first and the last beyond it).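

In this assay, replacing 4-methoxyphenyl with 3-(1-hydroxyethyl)phenyl on the saturated chain carbon bound to an aromatic nitrogen leaves compounds 3 and 4 indistinguishable (a 1.9-fold higher number from compound 3 to compound 4 (0.27 log units; within the scatter)), so this position accepts a group with a hydrogen-bond donor and a defined stereocentre without the sharp fall seen for compound 2. The new group also separates compound 4 from the other two: one gap is modest and only just clears the scatter (a 2.2-fold higher number from compound 1 to compound 4 (0.34 log units; beyond the scatter)), while the other is large (a 45-fold higher number from compound 2 to compound 4 (1.65 log units; beyond the scatter)). With only these compounds, the sharp fall remains confined to compound 2, and nothing measured here accounts for any of these differences.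

The compounds shown leave open whether the hydroxyl matters at all, which a plain ethyl group in place of the 1-hydroxyethyl would help to test, and whether the opposite arrangement at the stereocentre gives a similar number. They also leave open how this read-out responds when an amine or a carboxylic acid takes the place of the 1-hydroxyethyl group on the phenyl ring.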